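The source may hold more compounds than are shown below. What is called first, only, known or untested is meant among the compounds shown, and "the series" means these compounds.

Measured in a functional assay on NCI-H23 cells (Homo sapiens) for inhibition, read by sulforhodamine B assay, with a stated time of 48 h; a lower number here means a stronger inhibitor of growth, a higher number a weaker inhibitor of growth:
Compound 1 `CN1CCN(CCCOc2cccc3nc(Nc4ccc(Cl)c(C(F)(F)F)c4)ccc23)CC1` gives 1780 nM.
Compound 2 `CN1CCN(CCCOc2cccc3nc(Nc4ccc(Cl)c(F)c4)ccc23)CC1` gives 1750 nM.
Compound 3 `CN1CCN(CCCOc2cccc3nc(Nc4ccc(F)c(F)c4)ccc23)CC1` gives 4670 nM.

All three share one core and differ only in the ring attached to the nitrogen on the aromatic ring. Compound 3 gives the highest number of the three, so it is the weakest grower-inhibitor here: the step of a 2.6-fold higher number from compound 1 to compound 3 (0.42 log units; beyond the scatter) and the step of a 2.7-fold higher number from compound 2 to compound 3 (0.43 log units; beyond the scatter) both lie beyond the scatter, while a 1.0-fold lower number from compound 1 to compound 2 (0.01 log units; within the scatter) does not.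

Compound 4 `CN1CCN(CCCOc2cccc3nc(Nc4cc(Cl)cc(Cl)c4)ccc23)CC1` is the next compound. The change is 3,5-dichlorophenyl in place of 3,4-difluorophenyl on a nitrogen on an aromatic ring. Both fluorines leave and two chlorines enter, in a different arrangement on that ring. The step that bears most directly on this is a 2.7-fold higher number from compound 2 to compound 3 (0.43 log units; beyond the scatter), where a single fluoro in place of chloro raised the number modestly; the reverse direction is now taken, twice over, though at different places on the ring. The step of a 2.6-fold higher number from compound 1 to compound 3 (0.42 log units; beyond the scatter) points the same way. A modest lowering of the number, on the order of those steps, is therefore expected, a 2.5-fold lower number from compound 3 to compound 4 (0.39 log units; beyond the scatter). Compound 4 is estimated at 1900 nM, with a range from 800 nM to 5000 nM.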

Compound 4, concentration for 50% growth inhibition: 1720 nM
Estimate against measurement, compound 4: 1.1-fold (0.04 log units) above; measured number inside the range.
By their numbers in this assay, from the lowest: compounds 4, 2 and 1 (each within the scatter of the next); then compound 3.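

In this assay, 3,5-dichlorophenyl in place of 3,4-difluorophenyl gives a 2.7-fold lower number from compound 3 to compound 4 (0.43 log units; beyond the scatter) and leaves compound 3 as the only one set apart from the others. The comparisons a 1.0-fold lower number from compound 2 to compound 4 (0.01 log units; within the scatter) and a 1.0-fold lower number from compound 1 to compound 4 (0.01 log units; within the scatter) show no real separation, so a ring with no fluorine on it and no 4-chloro group, which both compound 1 and compound 2 carry, performs alike in this series. Nothing available explains why these rings fall as they do.

This step changes both the halogen and its arrangement on the ring, and the compounds shown do not separate those two changes. They also leave open how a plain phenyl ring, or a ring carrying a methoxy group or a nitrile, would behave at this position.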